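Cytotoxicity notes: pentyl chain in place of the aryl amide

The source may report more compounds than this note shows. Statements on the series, on what has been measured and on what is new or still open speak of the compounds shown alone.

Measured so far:
In an ADME assay on Vero cells (Chlorocebus sabaeus) for cytotoxicity, read by resazurin assay, with a stated time of 3 days (a lower number here means a stronger inhibitor, a higher number a weaker inhibitor), compound 1 (`COc1ccc(C(=O)Nc2cc3nc(C4CCCCC4)[nH]c3cc2N(C)C)cc1`) gives > 100 ug/mL, a limit of the assay.
In this assay compound 2 (`CCN(CC)c1cc2[nH]c(C3CCCCC3)nc2cc1NC(=O)c1ccc(F)cc1`) gives > 100 ug/mL, also a limit.
In this assay compound 3 (`CCCc1ccc(C(=O)Nc2cc3nc(C4CCCCC4)[nH]c3cc2N(C)C)cc1`) gives > 100 ug/mL, again a limit.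

Compound 3 therefore stands at the limit of > 100 ug/mL in this assay, at which 3 of the 3 values shown sit, alongside the other two. Within the data shown here, the only one-place step, a step that the two limits leave unreadable from compound 1 to compound 3, cannot be read in size, since both of its ends are limits.

Compound 4 (`CCCCCC(=O)Nc1cc2nc(C3CCCCC3)[nH]c2cc1N(C)C`) differs from compound 3 by pentyl in place of 4-propylphenyl on a carbonyl carbon. No measured step exchanges an aromatic group for a chain on the carbonyl carbon, so nothing shown bears directly on this change; the series offers only limits. Compound 4 is expected to remain at the limit as well, with an estimated value of 150 ug/mL, range 50 ug/mL to 500 ug/mL, which would mean an expected step that the limit leaves unreadable from compound 3 to compound 4.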

Compound 4, half-maximal inhibitory concentration: > 100 ug/mL
Compound 4: no number, only a limit (the forecaster's own chance of this, stated with the estimate: 75%); the middle value is on the limit's open side.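

Compound 4 sits at a limit, as do compound 1 and compound 3, so neither step to compound 4 can be read in size: the limit of > 100 ug/mL in this assay, at which 4 of the 4 values shown sit.

The compounds shown leave open whether any change on the carbonyl carbon alters the result in this assay.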